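The source may report more compounds than this note shows. Statements on the series, on what has been measured and on what is new or still open speak of the compounds shown alone.

Measured compounds:
Compound 1 `Cc1ccc(-c2nn(-c3ccccc3)cc2-c2nc3ccccc3n2S(=O)(=O)c2ccccc2)cc1`: 138000 nM
Compound 2 `O=S(=O)(c1ccccc1)n1c(-c2cn(-c3ccccc3)nc2-c2ccc(F)cc2)nc2ccccc21`: 96300 nM

Both compounds were tested in an ADME assay on HEK-293T cells (Homo sapiens) for cytotoxicity, read by MTT assay, with a stated time of 24 h; a higher number here means that more compound is tolerated, a lower number that less compound is tolerated. Only these two numbers are available, and compound 2 at 96300 nM lies within the scatter of compound 1 at 138000 nM, so neither can be separated from the other.

The next compound is compound 3 `O=S(=O)(c1ccc(F)cc1)n1c(-c2cn(-c3ccccc3)nc2-c2ccc(F)cc2)nc2ccccc21`, which keeps the structure of compound 2 except for one change: fluoro in place of hydrogen on an aromatic carbon, turning phenylsulfonyl into (4-fluorophenyl)sulfonyl (fluoro in place of hydrogen on an aromatic carbon). Going by the values given here, no measured step makes this exact change. The nearest evidence is a 1.4-fold lower number from compound 1 to compound 2 (0.16 log units; within the scatter), where fluoro replaces methyl on an aromatic carbon of a different ring. That step stayed within the scatter, so it offers only indirect support, and it gives no firm direction. In this assay, no shift beyond the scatter is therefore expected. The expected step is a 1.1-fold lower number from compound 2 to compound 3 (0.05 log units; within the scatter). For compound 3 the estimated value is 85000 nM, with an expected range of 42000 nM to 170000 nM.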

Compound 3, half-maximal cytotoxic concentration: 218000 nM
Compound 3: middle estimate off by 2.6-fold (0.41 log units), on the low side, and the stated range ends below it.
By their numbers in this assay, from the lowest: compounds 2, 1 and 3 (each within the scatter of the next, the first and the last beyond it).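

In this assay, going by these compounds alone, fluoro in place of hydrogen on the phenyl of the phenylsulfonyl group, which gives (4-fluorophenyl)sulfonyl, produces a 2.3-fold higher number from compound 2 to compound 3 (0.35 log units; beyond the scatter) and is the first single change here to lie beyond the scatter, though only modestly. The earlier change, a 1.4-fold lower number from compound 1 to compound 2 (0.16 log units; within the scatter) on a different ring, could not separate its two compounds, so this position on the phenylsulfonyl group is the first place shown where one added atom moves the number, and it moves towards more compound being tolerated. Nothing available here bears on why this fluoro has that effect.

The compounds shown leave open whether this step belongs to fluoro alone or would also appear with another group at the same place, such as chloro, methoxy or an amine. They also leave open whether the same change would give a similar step with the methyl-bearing ring of compound 1 in place of the 4-fluorophenyl ring of compound 2, since this single pair cannot establish a pattern across the series.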